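The source may report more compounds than this note shows. Statements on the series, on what has been measured and on what is new or still open speak of the compounds shown alone.

Measured compounds:
Compound 1, `O=C(CCc1cccc2c1B(O)OC2)Nc1ccc(Cl)cc1`, gives 12000 nM in a functional assay on HCT-116 cells (Homo sapiens) for antiproliferative activity, read by MTT assay, with a stated time of 72 h; on this read-out higher numbers stand for weaker inhibition and lower numbers for stronger inhibition.
Compound 2, `O=C(CCc1cccc2c1B(O)OC2)Nc1ccc(Br)cc1`, gives 46000 nM in this assay.
Compound 3, `O=C(CCc1cccc2c1B(O)OC2)Nc1cccc(I)c1`, gives 2300 nM in this assay.

Compound 3 stands lowest of the three numbers in this assay. Its nearest neighbour is compound 1, the step being a 5.2-fold lower number from compound 1 to compound 3 (0.72 log units; beyond the scatter), and the furthest is compound 2, the step being a 20-fold lower number from compound 2 to compound 3 (1.30 log units; beyond the scatter). Between the other two compounds the step is a 3.8-fold higher number from compound 1 to compound 2 (0.58 log units; beyond the scatter).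

Compound 4, `CSc1ccc(-c2cccc(NC(=O)CCc3cccc4c3B(O)OC4)c2)cc1`, differs from compound 3 in a single place: 4-(methylsulfanyl)phenyl in place of iodo on an aromatic carbon.

None of the three measured steps bears closely on this change. Going by the values given here, the step from compound 1 to compound 2 exchanges one halogen for another, and the two steps leading to compound 3 exchange one halogen-bearing phenyl for another; no measured pair puts an aromatic group in place of a halogen. The measured steps are therefore of little help in fixing a direction, and the expectation is for a number near that of compound 3, with a wide range on either side. On that basis compound 4 is expected to give about 3000 nM in this assay, between 600 nM and 15000 nM, which amounts to an expected step of a 1.3-fold higher number from compound 3 to compound 4 (0.12 log units; within the scatter).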

Compound 4, half-maximal inhibitory concentration: 180 nM
Beside the measured number, compound 4's estimate is 17-fold (1.22 log units) above it; measured number outside the range, below it.
By their numbers in this assay, from the lowest: compound 4; then compound 3; then compound 1; then compound 2.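

In this assay, the aromatic carbon that carries the iodo group in compound 3 accepts a much larger substituent: putting 4-(methylsulfanyl)phenyl there gives a 13-fold lower number from compound 3 to compound 4 (1.11 log units; beyond the scatter), a large move towards stronger inhibition. The earlier compounds shown here exchanged only one halogen-bearing phenyl for another, so they could show nothing about replacing a single iodine atom with a group of eight heavy atoms that brings a whole further aromatic ring, and here that enlargement does not cost activity but goes with a lower number. Nothing available explains this gain, and no measurement here says what the added group does to produce it.

The compounds shown leave open whether the lower number goes with the added phenyl ring alone or needs the methylsulfanyl group on it, and how a methoxy group, a dimethylamino group or a carboxylic acid would read in place of that methylsulfanyl group. They also leave open whether a longer chain linking the carbonyl to the shared core would keep the number seen with this substituent.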